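The source may hold more compounds than are shown below. What is called first, only, known or untested is meant among the compounds shown, and "the series" means these compounds.

Of the compounds shown here, three sharing one core have been measured in an assay on CHO cells for displacement of a labelled ligand from corticotropin-releasing factor receptor 1 (Homo sapiens), read by scintillation counting, with a stated time of 1.5 h; on this read-out higher numbers stand for weaker inhibition and lower numbers for stronger inhibition. Compound 1 `CCN(CC)c1ccc(OC)c2nc(Nc3c(C)cc(Cl)cc3OC)n(C)c12` gives 13 nM. Compound 2 `CCCN(CCC)c1ccc(C#N)c2nc(Nc3c(C)cc(Cl)cc3OC)n(C)c12` gives 14 nM. Compound 3 `CCN(CC)c1ccc(C)c2nc(Nc3c(C)cc(Cl)cc3OC)n(C)c12` gives 7.6 nM, the lowest of the three numbers, though its gaps to compound 1 and to compound 2 both lie within the scatter, so no order among them can be read. Among the measured compounds shown here, the only step between measured compounds that differ in a single place is a 1.7-fold lower number from compound 1 to compound 3 (0.23 log units; within the scatter), a change too small to count.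

Compound 4 `CCN(CC)c1ccc(C#N)c2nc(Nc3c(C)cc(Cl)cc3OC)n(C)c12` has not been measured. It differs from compound 3 in one place: cyano in place of methyl on an aromatic carbon. For the measured compounds named here, no measured pair shows exactly this swap. Compound 2 carries the same cyano group, but with a dipropylamino group in place of diethylamino, and gives 14 nM; compound 1 carries a methoxy group on that carbon and gives 13 nM. All three substituents tried on this carbon thus give numbers within the scatter of one another. The expected step is therefore small, a 1.4-fold higher number from compound 3 to compound 4 (0.16 log units; within the scatter), with no clear direction. Compound 4 is estimated at 11 nM, with a range from 5 nM to 25 nM.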

Compound 4, half-maximal inhibitory concentration: 13 nM
Compound 4: the middle estimate sits 1.2-fold (0.07 log units) below what was measured; the measured number falls inside the stated range.
By their numbers in this assay, from the lowest: compounds 3, 1, 4 and 2 (each within the scatter of the next).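

The direct swap at the aromatic carbon para to the diethylamino group now has a measured step in this assay: a 1.7-fold higher number from compound 3 to compound 4 (0.23 log units; within the scatter) for cyano in place of methyl. With the diethylamino group held fixed, cyano in place of methoxy gives no change at the digits printed from compound 1 to compound 4 (within the scatter), so methyl, methoxy and cyano can now be compared on this carbon in otherwise identical compounds, and the data cannot tell them apart, even though cyano brings one more heavy atom than methyl and a hydrogen-bond acceptor. Among the compounds shown here, the cyano compounds also give the first single-place comparison of the two amine groups, with a 1.1-fold lower number from compound 2 to compound 4 (0.03 log units; within the scatter) for diethylamino in place of dipropylamino, so these two chains cannot be told apart either, at least when cyano occupies the other position.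

Whether any group on this carbon can move the number beyond the scatter stays open, since a carboxylic acid, an amine or a plain hydrogen there is not among the compounds shown, and neither is a chain longer than propyl on the nitrogen. Nothing measured here offers an explanation for how closely these numbers sit together.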